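The compounds below may be only part of what the source reports. "The series", "measured", "known", "first", "only" and "open" are said of these compounds alone.

Going by the values given here, in an ADME assay on Jurkat cells (Homo sapiens) for cytotoxicity, read by MTT assay, with a stated time of 72 h (on this read-out higher numbers stand for weaker inhibition and lower numbers for stronger inhibition), compound 3 `CCNC(=O)c1cnc(Oc2ccc3c(c2)B(O)OC3)cn1` gives 79900 nM, the only true number in this small set. Compound 1 `COC(=O)c1ccc(Oc2ccc3c(c2)B(O)OC3)cn1`, which carries an ester, gives > 100000 nM, and this is a limit of the assay rather than a number. Compound 2 `O=C(O)c1cnc(Oc2ccc3c(c2)B(O)OC3)cn1` gives > 100000 nM, which is also a limit.

The next compound, compound 4 `CCOC(=O)c1cnc(Oc2ccc3c(c2)B(O)OC3)cn1`, keeps the shared core and changes one group, from ethylcarbamoyl to ethoxycarbonyl: ethoxy in place of ethylamino on a carbonyl carbon. The new group is ethoxy in place of ethylamino on a carbonyl carbon.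

Among the compounds with values here, one measured step bears on this, as it also changes the group on that carbonyl carbon. It is an at least 1.2-fold lower number from compound 2 to compound 3 (0.09 log units; that floor lies within the scatter), so this kind of change has not yet shown an effect beyond the scatter. A similarly small move is therefore expected in this assay, perhaps slightly towards weaker inhibition. The estimated step is a 1.1-fold higher number from compound 3 to compound 4 (0.05 log units; within the scatter), which would not be a clear change.

For compound 4 the expected value is 90000 nM, with an estimated range from 45000 nM to 170000 nM.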

Compound 4, half-maximal inhibitory concentration: 16800 nM
The estimate for compound 4 lay 5.4-fold (0.73 log units) above the measured number; measured number below the stated range.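

Ethoxy in place of ethylamino on a carbonyl carbon gives a 4.8-fold lower number from compound 3 to compound 4 (0.68 log units; beyond the scatter) in this assay, so the atom that joins the ethyl group to the carbonyl carbon matters at this position, and the lower number means stronger inhibition of cell growth. Ethyl in place of hydrogen on an oxygen next to a carbonyl group gives an at least 5.9-fold lower number from compound 2 to compound 4 (0.77 log units; beyond the scatter), so the ethyl ester also stands clear of the carboxylic acid, which the earlier step to the amide could not show. From the compounds shown here alone, the true size of this second step stays unknown, as it is only a floor set by a limit: the limit of > 100000 nM in this assay, at which 2 of the 4 values shown sit.

The compounds shown cannot separate the effect of the oxygen from that of the hydrogen-bond donor lost with ethylamino. They also leave open whether a longer chain such as butoxy, or a dimethylamino group, on the same carbonyl carbon would follow the ester or the amide.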